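This account rests on a few compounds, and the source may have more. Where it says the series, first, only, none or still open, it means among the compounds named here.

Series notes. Compound 1 `N#Cc1ccc(NC(=O)c2cc(-c3ccccc3)ccc2O)cc1` gives 1350 nM in a functional assay on HL-60 cells (Homo sapiens) for cytotoxicity, read by luminescence and CellTiter-Glo, with a stated time of 3 days (a higher number here means a weaker inhibitor, a lower number a stronger inhibitor), the highest of the three numbers in hand. Compound 3 `N#Cc1ccc(NC(=O)c2ccc(-c3ccccc3)cc2O)cc1` stands at 700 nM in this assay, within the scatter of compound 1. Compound 2 `O=C(Nc1ccc([N+](=O)[O-])cc1)c1cc(F)ccc1O` gives 520 nM in this assay, and its gap from compound 1 lies beyond the scatter. Compound 4 `N#Cc1ccc(NC(=O)c2cc(Br)ccc2O)cc1` is not yet measured; it differs from compound 1 in one place: bromo in place of phenyl on an aromatic carbon. Among the measured compounds shown here, no pair of measured compounds isolates this change, so nothing in hand sets its direction firmly. For compound 4 a modest step toward a lower number is expected, a 1.7-fold lower number from compound 1 to compound 4 (0.23 log units; within the scatter), though an outcome within the scatter would not surprise. Compound 4 is estimated at 800 nM, in the range 300 nM to 2500 nM.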

Compound 4, half-maximal inhibitory concentration: 620 nM
The estimate for compound 4 lay 1.3-fold (0.11 log units) above the measured number, and the stated range covers the measured number.
By their numbers in this assay, from the lowest: compounds 2, 4, 3 and 1 (each within the scatter of the next, the first and the last beyond it).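

In this assay, the aromatic carbon para to the hydroxy group accepts a much smaller group: bromo in place of phenyl gives a 2.2-fold lower number from compound 1 to compound 4 (0.34 log units; beyond the scatter), a modest step. The six-carbon phenyl ring is therefore not required at this position for a number in this range, and a single bromine atom serves there. Nothing in hand accounts for the size or direction of this step. As far as these compounds go, how hydrogen, chloro, methoxy or an amine would read at this carbon stays open, so the step cannot yet be assigned to losing the phenyl or to gaining the bromine.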